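Shortening a saturated chain on the core of compound 1

The compounds below may be only part of what the source reports. "The series", "measured", "known", "first", "only" and "open" are said of these compounds alone.

Compound 1, `CCCC1Nc2ccc(C(C)C)cc2C(=O)N1Cc1ccc(-c2ccccc2-c2nn[nH]n2)cc1`: 50 nM
Compound 2, `CCCCC1Nc2ccc(C(C)C)cc2C(=O)N1Cc1ccc(-c2ccccc2-c2nn[nH]n2)cc1`: 1100 nM
Compound 3, `CCCCC1N(Cc2ccc(-c3ccccc3-c3nn[nH]n3)cc2)C(=O)c2ccccc2N1C`: 14000 nM

In an assay on adrenal cortex for inhibition of angiotensinogen (Rattus norvegicus) (on this read-out lower numbers stand for stronger inhibition and higher numbers for weaker inhibition), compound 1 stands lowest of the three numbers shown, which on this read-out means the strongest inhibition. Its nearest neighbour is compound 2; compound 3 lies furthest away, and both gaps are beyond the scatter. Within the data shown here, only one measured step concerns a single change at the saturated chain: a 22-fold higher number from compound 1 to compound 2 (1.34 log units; beyond the scatter), where a methyl replaced a hydrogen three bonds along the chain from a saturated ring carbon, so that lengthening the chain by one carbon made the inhibition clearly weaker.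

Compound 4, `CCC1Nc2ccc(C(C)C)cc2C(=O)N1Cc1ccc(-c2ccccc2-c2nn[nH]n2)cc1`, goes the other way along the same chain. It differs from compound 1 by hydrogen in place of methyl on a saturated chain carbon, two bonds along the chain from a saturated ring carbon, so the chain is one carbon shorter rather than longer. Among the measured compounds shown here, no measured pair shows what removing a carbon here does. Lengthening was costly, but that alone does not say whether shortening is rewarded or punished. The expectation for compound 4 is therefore a modest step, a 2.0-fold higher number from compound 1 to compound 4 (0.30 log units; within the scatter), with a wide range on either side. Compound 4 is estimated at 100 nM, between 25 nM and 400 nM.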

Compound 4, half-maximal inhibitory concentration: 90 nM
The estimate for compound 4 lay 1.1-fold (0.05 log units) above the measured number; measured number inside the range.
By their numbers in this assay, from the lowest: compounds 1 and 4 (each within the scatter of the next); then compound 2; then compound 3.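

In this assay, cutting the chain from propyl to ethyl gives a 1.8-fold higher number from compound 1 to compound 4 (0.26 log units; within the scatter), so the carbon that leaves can be removed without a change that stands out from repeat-measurement noise. The earlier compounds shown here showed only that adding a carbon to the propyl chain is costly; the new step shows that the effect at this position is lopsided, with a 12-fold lower number from compound 2 to compound 4 (1.09 log units; beyond the scatter) confirming that the ethyl chain, like the propyl chain, sits far from the butyl chain on the number scale. Among these three chains, ethyl and propyl cannot be told apart and only butyl stands apart, although nothing available explains why the extra carbon matters so much at this position.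

The compounds shown leave open how far the shortening can go, since a methyl group, or a bare hydrogen, on the same saturated ring carbon would test whether the ethyl chain is already near a limit. They also leave open whether the carbon count alone decides the outcome, which a branched isopropyl group or a cyclopropyl ring at this place could help to separate.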